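A carbamoyl group added to the weaker compound

This account rests on a few compounds, and the source may have more. Where it says the series, first, only, none or still open, it means among the compounds named here.

Within the data shown here, in a functional assay (aorta) for inhibition, with Rattus norvegicus as the target (on this read-out higher numbers stand for weaker inhibition and lower numbers for stronger inhibition), compound 2 `C/N=C(\S)[C@]1(c2ccccc2)CCCC[S+]1[O-]` gives 9500 nM, the higher of the two numbers so far, so it is the weaker inhibitor. Compound 1 `C/N=C(\S)[C@]1(c2cccc(C(F)(F)F)c2)CCCC[S+]1[O-]` gives 800 nM. Compound 3 `C/N=C(\S)[C@]1(c2cccc(C(N)=O)c2)CCCC[S+]1[O-]` keeps the core of compound 2 but carries a new group: carbamoyl in place of hydrogen on an aromatic carbon. That is carbamoyl in place of hydrogen on an aromatic carbon, meta to a large group. Among the measured compounds shown here, only one measured step bears on this change, and it is large and beyond the scatter: a 12-fold higher number from compound 1 to compound 2 (1.07 log units; beyond the scatter). For the measured compounds named here, it shows that hydrogen gave the higher number in that pair, but it involves trifluoromethyl, and no carbamoyl compound has been measured yet. A drop in the number is therefore expected, though a smaller one. The expected change is a 3.2-fold lower number from compound 2 to compound 3 (0.50 log units; beyond the scatter). For compound 3 the estimated value is 3000 nM, with an expected range of 700 nM to 12000 nM.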

Compound 3, concentration for 90% inhibition: 12000 nM
Compound 3: middle estimate off by 4.0-fold (0.60 log units), on the low side, and the stated range covers the measured number.
By their numbers in this assay, from the lowest: compound 1; then compounds 2 and 3 (each within the scatter of the next).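

On an aromatic carbon meta to a large group, the lower number seen with trifluoromethyl does not carry over to carbamoyl: in this assay, carbamoyl in place of hydrogen gives a 1.3-fold higher number from compound 2 to compound 3 (0.10 log units; within the scatter) and the two compounds cannot be told apart. Carbamoyl in place of trifluoromethyl gives a 15-fold higher number from compound 1 to compound 3 (1.18 log units; beyond the scatter) and shows that a group at this position does not lower the number merely by replacing hydrogen; which group stands there matters. Nothing available explains why these two groups differ.

The compounds shown leave open whether a chlorine atom, a nitrile or a carboxylic acid at this position would give a number like that of trifluoromethyl or one like that of carbamoyl. They also leave open how trifluoromethyl would behave elsewhere on the aromatic ring.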